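The source may report more compounds than this note shows. Statements on the series, on what has been measured and on what is new or still open speak of the compounds shown alone.

Of the compounds shown here, two built on one shared core have been measured in a functional assay for inhibition of sodium- and chloride-dependent glycine transporter 1 (Rattus norvegicus), with a stated time of 30 min, in the presence of a further agent that is not named here; a lower number here means a stronger inhibitor, a higher number a weaker inhibitor. Compound 1 `CC(C)(C)c1ccc(/C(=C\CC(N)C(=O)O)c2ccc(F)cc2F)cc1` carries a tert-butyl group on an aromatic carbon. In this assay compound 1 gives > 10000 nM, which is a limit of the assay and not a number. Compound 2 `CCc1ccc(/C(=C\CC(N)C(=O)O)c2ccc(F)cc2F)cc1` carries an ethyl group instead. In this assay compound 2 gives > 10000 nM, again a limit rather than a number. For the measured compounds named here, the single measured step, a step that the two limits leave unreadable from compound 1 to compound 2, cannot be read because of the limit of > 10000 nM in this assay, at which 2 of the 2 values shown sit. Compound 3 `NC(C/C=C(\c1cccnc1)c1ccc(F)cc1F)C(=O)O` is still unmeasured; here (pyridin-3-yl in place of 4-ethylphenyl on a double-bonded chain carbon bound to an aromatic carbon and a double-bonded chain carbon). No readable step bears on this change, so the expected step from compound 2 to compound 3 is a number no higher from compound 2 to compound 3 (the limit leaves the size open), with the reading expected to stay at the limit. For compound 3 the estimate in this assay is 10000 nM, ranging from 2000 nM to 50000 nM.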

Compound 3, half-maximal inhibitory concentration: > 10000 nM
Compound 3: a limit, no number; the forecaster's own chance of this, stated with the estimate: 70%; the middle value lies on the limit itself.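

The step from compound 2 to compound 3 cannot be read, because both compounds sit at a limit of the assay and not at a number: the limit of > 10000 nM in this assay, at which 3 of the 3 values shown sit. Compound 1, compound 2 and compound 3 leave open how strongly each inhibits the transporter and whether changing these groups alters that strength.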